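Exchanging the terminal aryl group on a shared core

The compounds below may be only part of what the source reports. "The series", "measured", "known", "first", "only" and "open" are said of these compounds alone.

The three measured compounds share one core and differ only in the group attached to an aromatic carbon at its far end. Compound 1 `CCC(C)(C)Cc1c[nH]c(CCc2ccc(-c3ccncc3)cc2)n1` gives 103 nM in a functional assay on HEK293 cells for agonist activity at Bombesin receptor subtype-3 (Mus musculus), read by luminescence and calcium flux, with a stated time of 10 min; on this read-out lower numbers stand for an effect already at smaller amounts and higher numbers for an effect only at larger amounts of compound. Compound 2 `CCC(C)(C)Cc1c[nH]c(CCc2ccc(-n3cccn3)cc2)n1` gives 113 nM in this assay, and compound 3 `CCC(C)(C)Cc1c[nH]c(CCc2ccc(-c3ccccc3C(=O)O)cc2)n1` gives 94 nM in this assay. Compound 3 holds the lowest of the three numbers, but the steps leading to it are small: a 1.1-fold lower number from compound 1 to compound 3 (0.04 log units; within the scatter) and a 1.2-fold lower number from compound 2 to compound 3 (0.08 log units; within the scatter), both within the scatter, and the same holds for a 1.1-fold higher number from compound 1 to compound 2 (0.04 log units; within the scatter).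

Compound 4 `CCC(C)(C)Cc1c[nH]c(CCc2ccc(-c3cccc(N)n3)cc2)n1` has not yet been measured. It differs from compound 3 in one place: 6-aminopyridin-2-yl in place of 2-carboxyphenyl on an aromatic carbon. The two steps that bear on this change, from compound 1 and from compound 2 to compound 3, show that swapping this terminal group has so far left the number essentially unchanged. Compound 4 is therefore expected to show a step of about a 1.1-fold higher number from compound 3 to compound 4 (0.03 log units; within the scatter), which is none beyond the scatter. The estimate for compound 4 in this assay is 100 nM, with a range from 40 nM to 250 nM.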

Compound 4, half-maximal effective concentration: 119 nM
The estimate for compound 4 lay 1.2-fold (0.08 log units) below the measured number; measured number inside the range.
By their numbers in this assay, from the lowest: compounds 3, 1, 2 and 4 (each within the scatter of the next).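

Compound 4 carries the same message to a fourth terminal group in this assay: the steps are a 1.3-fold higher number from compound 3 to compound 4 (0.10 log units; within the scatter) and a 1.1-fold higher number from compound 2 to compound 4 (0.02 log units; within the scatter) and a 1.2-fold higher number from compound 1 to compound 4 (0.06 log units; within the scatter). The comparison with compound 3 adds that, at this place on an aromatic carbon para to a large group, 6-aminopyridin-2-yl with 7 heavy atoms and a ring with 1 hetero atom reads no differently from 2-carboxyphenyl with 9 heavy atoms and a ring of carbon only. Nothing available explains why these exchanges leave the number within the scatter.

As far as these compounds go, all four compounds keep an aromatic ring at this place, so the effect of a methyl group or a bare hydrogen there stays open. Also open, from the compounds shown here alone, is whether a shorter chain elsewhere on the shared core would change the number.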